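Ester chain extension in the phenolic series

This account rests on a few compounds, and the source may have more. Where it says the series, first, only, none or still open, it means among the compounds named here.

Compound 1 `COC(=O)c1cc(-n2cc(-c3cc(O)ccc3O)nn2)ccc1O` serves as the reference point. In a functional assay on HCT-116 cells (Homo sapiens) for inhibition, read by MTT assay, with a stated time of 2 days, tested at 10 uM (on this read-out lower numbers stand for less inhibition and higher numbers for more inhibition at the one concentration tested (going by the name of the read-out)), compound 1 gives 15%, the highest of the three numbers recorded, but with gaps to both other compounds that stay within the usual scatter. Compound 2 `COC(=O)c1cc(-n2cc(-c3ccc(OC)cc3)nn2)ccc1O` gives 6%, and compound 3 `COc1ccc(-c2cn(-c3ccc(O)c(C(=O)Nc4cccc(C(F)(F)F)c4)c3)nn2)cc1` gives 9%.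

Two single-point changes have been measured. Replacing the 2,5-dihydroxyphenyl by a 4-methoxyphenyl on an aromatic carbon gave a number 9 percentage points lower from compound 1 to compound 2 (within the scatter). Replacing the methoxy on the carbonyl carbon by a (3-(trifluoromethyl)phenyl)amino gave a number 3 percentage points higher from compound 2 to compound 3 (within the scatter). Neither step moved beyond the scatter; the second is the one that touches the ester region and so bears most directly on the next compound.

Compound 4 `O=C(OCCCc1ccccc1)c1cc(-n2cc(-c3cc(O)ccc3O)nn2)ccc1O` differs from compound 1 by phenethyl in place of hydrogen on a saturated chain carbon bound to an oxygen next to a carbonyl group. Among the compounds with values here, since the only change made so far at the carbonyl position, the step from compound 2 to compound 3, stayed within the scatter, no step beyond the scatter is expected here either, in either direction. Compound 4 is therefore estimated to give 16%, with a range from 0% to 35%, which corresponds to an expected step of a number 1 percentage points higher from compound 1 to compound 4 (within the scatter).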

Compound 4, a percentage reported as inhibition, at one concentration (the size of the read-out at that concentration, not a potency): 39%
Estimate against measurement, compound 4: 23 percentage points below, outside the stated range (above it).
By their numbers in this assay, from the lowest: compounds 2, 3 and 1 (each within the scatter of the next); then compound 4.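

In this assay, within the data shown here, the change from methoxy to 3-phenylpropoxy gives a number 24 percentage points higher from compound 1 to compound 4 (beyond the scatter), the only step so far to leave the scatter; a number 9 percentage points lower from compound 1 to compound 2 (within the scatter) and a number 3 percentage points higher from compound 2 to compound 3 (within the scatter) both stay inside it. This position on the core of compound 1 therefore accepts a chain ending in an aromatic ring without loss at the one concentration tested, and the read-out responds to the change here, with the 2,5-dihydroxyphenyl held constant, in a way that the amide step on the 4-methoxyphenyl background gave no sign of. No data at hand bear on why the number rises.

Still open, going by these compounds, is whether the gain needs the terminal phenyl ring or only the chain, which a plain n-propyl or a benzyl or 5-phenylpentyl group in the same place would separate, and whether a terminal amine on the chain would be accepted. Also open, on these data alone, are whether 3-phenylpropoxy gives a similar step with the 4-methoxyphenyl of compound 2 in place of the 2,5-dihydroxyphenyl, and whether the single-concentration number of compound 4 reflects potency.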